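This account rests on a few compounds, and the source may have more. Where it says the series, first, only, none or still open, it means among the compounds named here.

Compound 1 `O=C(Nc1ccc(Cl)c(-c2nnc3c(Cl)cccn23)c1)c1ccc(C(F)(F)F)cc1Cl`: in a functional assay on A549 cells (Homo sapiens) for antiproliferative activity, read by MTT assay, with a stated time of 72 h (on this read-out lower numbers stand for stronger inhibition and higher numbers for weaker inhibition), compound 1 gives > 100000 nM, which is a limit of the assay.
Compound 2 `O=C(Nc1ccc(Cl)c(-c2nnc3c(Cl)cccn23)c1)c1ccc(Cl)cc1`: in this assay compound 2 gives 73600 nM.
Compound 3 `CS(=O)(=O)c1ccc(C(=O)Nc2ccc(Cl)c(-c3nnc4c(Cl)cccn34)c2)c(Cl)c1`: in this assay compound 3 gives > 100000 nM, again a limit.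

Going by the values given here, compound 2 thus stands as the only number among the three; the other two values are limits. Compound 4 `O=C(Nc1ccc(Cl)c(-c2nnc3c(Cl)cccn23)c1)c1c(F)cccc1Cl` differs from compound 2 by 2-chloro-6-fluorophenyl in place of 4-chlorophenyl on a carbonyl carbon. Among the compounds with values here, the only measured step, a step that the two limits leave unreadable from compound 1 to compound 3, also alters the ring on the carbonyl carbon but is unreadable because both of its ends sit at the limit of > 100000 nM in this assay, at which 2 of the 3 values shown sit. No readable step therefore bears on the change, and the expected step is a 1.1-fold higher number from compound 2 to compound 4 (0.04 log units; within the scatter), within the scatter. Compound 4 is accordingly estimated at 80000 nM, in a range from 20000 nM to 300000 nM, with a fair chance that only a limit is reported.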

Compound 4, half-maximal inhibitory concentration: 72300 nM
The estimate for compound 4 lay 1.1-fold (0.04 log units) above the measured number; the range from low to high includes it.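

Going by these compounds alone, on the carbonyl carbon, 2-chloro-6-fluorophenyl in place of 4-chlorophenyl gives the first readable step in this assay, a 1.0-fold lower number from compound 2 to compound 4 (0.01 log units; within the scatter). The number therefore does not separate these two chlorine-bearing phenyl groups, although they differ in the fluorine they carry. The step between compound 1 and compound 3 still cannot be read, as both of its ends are limits: the limit of > 100000 nM in this assay, at which 2 of the 4 values shown sit.

From the compounds shown here alone, it remains open whether a phenyl ring carrying an amine or a carboxylic acid would move the number. The same holds for a saturated alkyl chain on the carbonyl carbon.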